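Working notes: from compound 3 to compound 4

The source may hold more compounds than are shown below. What is called first, only, known or untested is meant among the compounds shown, and "the series" means these compounds.

Compound 1 `CNC(=N)Nc1nc(-c2ccc(OC)cc2)c(-c2ccc(OC)cc2)s1` gives 1.2 uM in a functional assay (aorta) with Rattus norvegicus as the target; a higher number here means that more compound is needed for the effect, a lower number that less compound is needed
Compound 2 `C/N=C(/NC)Nc1nc(-c2ccc(OC)cc2)c(-c2ccc(OC)cc2)s1` gives 2.4 uM in this assay
Compound 3 `COc1ccc(-c2nc(CNC(C)=O)sc2-c2ccc(OC)cc2)cc1` gives 8.1 uM in this assay

Compound 3 has the highest number of the three. The measured steps to it are a 6.8-fold higher number from compound 1 to compound 3 (0.83 log units; beyond the scatter) and a 3.4-fold higher number from compound 2 to compound 3 (0.53 log units; beyond the scatter), and both replace a whole group on an aromatic carbon. Compound 4 `CNC(=O)NCc1nc(-c2ccc(OC)cc2)c(-c2ccc(OC)cc2)s1` differs from compound 3 by methylamino in place of methyl on a carbonyl carbon. Among the measured compounds shown here, no measured step makes this exact change. The closest in size is a 2.0-fold higher number from compound 1 to compound 2 (0.30 log units; within the scatter), on another group, so only a small shift is expected in this assay. The estimated step is a 1.2-fold lower number from compound 3 to compound 4 (0.06 log units; within the scatter), with none expected beyond the scatter. The estimated value for compound 4 is 7 uM, with an expected range of 3 uM to 16 uM.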

Compound 4, concentration for half-maximal effect: 15 uM
Compound 4: middle estimate off by 2.1-fold (0.33 log units), on the low side, and the stated range covers the measured number.
By their numbers in this assay, from the lowest: compounds 1 and 2 (each within the scatter of the next); then compounds 3 and 4 (each within the scatter of the next).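

In this assay, methylamino in place of methyl on the carbonyl carbon gives a small shift (a 1.9-fold higher number from compound 3 to compound 4 (0.27 log units; within the scatter)), so this change does not separate the two compounds. The ((methylcarbamoyl)amino)methyl group remains clearly apart from the groups on the aromatic carbon in the two more sensitive compounds (a 6.3-fold higher number from compound 2 to compound 4 (0.80 log units; beyond the scatter); a 13-fold higher number from compound 1 to compound 4 (1.10 log units; beyond the scatter)). No supporting data explain these differences.

The compounds shown leave open whether ethylamino or dimethylamino on the carbonyl carbon would move the number beyond the scatter. They also leave open how a carboxylic acid or a longer chain would read in place of the acetamidomethyl group.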